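A few compounds are considered here, and "the series" means these few. Any claim that something is new, unique, unknown or untested is made for them only; others in the source may bear on it.

Compound 1 `CCn1c(/C=C2/C(=O)Nc3ccccc32)nc2ccccc21` is the unsubstituted parent of this small set. In a functional assay on MDA-MB-231 cells (Homo sapiens) for cytotoxicity, read by MTT assay, with a stated time of 48 h (on this read-out lower numbers stand for stronger inhibition and higher numbers for weaker inhibition), compound 1 gives > 50000 nM, and this is a limit of the assay rather than a number. Compound 2 `CCn1c(/C=C2/C(=O)Nc3ccc(Br)cc32)nc2ccccc21` carries a bromo group on the shared core. In this assay compound 2 is recorded as "not determined" (no result reported), so no number of its own places it. What surrounds compound 2 is a single further value, and that value is the limit (the limit of > 50000 nM in this assay, at which 1 of the 2 values shown sits). Compound 3 `CCn1c(/C=C2/C(=O)Nc3ccc(F)cc32)nc2ccccc21` differs from compound 2 by fluoro in place of bromo on an aromatic carbon. Going by the values given here, no measured step covers this exchange, so the size of the step in this assay cannot be read from the data; the only anchor is the limit at which compound 1 sits, and the expectation is of no step beyond the scatter. On that footing compound 3 is estimated at 50000 nM, with a range from 15000 nM to 100000 nM, most likely reported as a limit again.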

Compound 3, half-maximal inhibitory concentration: > 50000 nM
Compound 3 ended at the assay's limit; the forecaster's own chance of this, stated with the estimate: 70%; the middle value lies on the limit itself.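

No step can be read from compound 1 to compound 3, since both values are limits of the assay: the limit of > 50000 nM in this assay, at which 2 of the 3 values shown sit.

The compounds shown leave open whether fluoro, bromo or any other group on the shared core would give an actual number in this assay.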